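Ester aryl swap on the flavonol series

The source may report more compounds than this note shows. Statements on the series, on what has been measured and on what is new or still open speak of the compounds shown alone.

The two measured compounds share one core. Compound 1 `C=CCCOc1cc(O)c2c(=O)c(O)c(-c3ccc4c(c3)OC(c3ccc(OCCC=C)c(OC)c3)C(CO)O4)oc2c1` carries a free hydroxymethyl and two but-3-enyloxy groups; in a functional assay on liver (Rattus norvegicus, strain Sprague-Dawley) for inhibition, with a stated time of 1 h (a lower number here means a stronger inhibitor, a higher number a weaker inhibitor), compound 1 gives 36200 nM. Compound 2 `COc1cc(C2Oc3cc(-c4oc5cc(O)cc(O)c5c(=O)c4O)ccc3OC2COC(=O)c2cccc(Cl)c2)ccc1O` has the hydroxymethyl esterified and in this assay compound 2 gives 16900 nM, the lower of the two numbers and beyond the scatter from compound 1. Compound 3 `COc1ccc(C(=O)OCC2Oc3ccc(-c4oc5cc(O)cc(O)c5c(=O)c4O)cc3OC2c2ccc(O)c(OC)c2)cc1` is the ester analogue to be measured next. For the measured compounds named here, its single difference from compound 2 is 4-methoxyphenyl in place of 3-chlorophenyl on a carbonyl carbon. Going by the values given here, no measured pair isolates this kind of change, so the size of the step is open; one aryl group of similar size replaces another on the ester carbonyl, and no step beyond the scatter is expected in either direction. Compound 3 is therefore estimated at 20000 nM in this assay, within 8000 nM to 50000 nM, which means an expected step of a 1.2-fold higher number from compound 2 to compound 3 (0.07 log units; within the scatter).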

Compound 3, half-maximal inhibitory concentration: 104000 nM
For compound 3 the middle estimate is 5.2-fold (0.72 log units) below the measured one, outside the stated range (above it).
By their numbers in this assay, from the lowest: compound 2; then compound 1; then compound 3.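

In this assay, the aryl group on the ester carbonyl is not interchangeable: 4-methoxyphenyl in place of 3-chlorophenyl gives a 6.2-fold higher number from compound 2 to compound 3 (0.79 log units; beyond the scatter). For the compounds shown here, this is the first measured pair to isolate a change at this position, and it shows that one aryl group of similar size can separate two esters by more than the scatter. No measurement available here bears on the origin of this step.

The pair changes the identity of the substituent and its ring position together, so it leaves open whether the difference follows from losing the 3-chlorophenyl group or from introducing the 4-methoxyphenyl group. On these data alone, a plain phenyl group on the same carbonyl carbon would give a reference point for both esters, and the direction of the step with it remains open.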